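The source may hold more compounds than are shown below. What is called first, only, known or untested is meant among the compounds shown, and "the series" means these compounds.

Two compounds have been measured in a functional assay on Jurkat cells (Homo sapiens) for inhibition, read by MTT assay, tested at 10 uM; on this read-out lower numbers stand for less inhibition and higher numbers for more inhibition at the one concentration tested (going by the name of the read-out):

Compound 1, `CC1Cc2ccccc2N1S(=O)(=O)c1ccc(-c2cnc(C3CC3)o2)cc1`, gives 89.9%.
Compound 2, `Cc1ccc2c(c1)CCN2S(=O)(=O)c1ccc(-c2cnc(C3CC3)o2)cc1`, gives 91.1%.

Compound 2 is the starting point here. Its value and that of compound 1 lie within the usual scatter of each other, so the two compounds cannot be told apart on these numbers: both stand at a high level of inhibition at the single concentration tested.

Compound 3, `CS(=O)(=O)c1ccc2c(c1)CCN2S(=O)(=O)c1ccc(-c2cnc(C3CC3)o2)cc1`, has not yet been measured. It differs from compound 2 in one place: methylsulfonyl in place of methyl on an aromatic carbon. For the measured compounds named here, no pair of measured compounds differing in a single place is available, so there is no measured step to guide what this change does.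

The expectation rests only on the two values already seen. A step of a number 7.1 percentage points lower from compound 2 to compound 3 (within the scatter) in this assay is expected, small and downward, and not clearly beyond the scatter. For compound 3 the estimated value is 84%, with a range from 60% to 96%.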

Compound 3, a percentage reported as inhibition, at one concentration (the size of the read-out at that concentration, not a potency): 13%
Estimate against measurement, compound 3: 71 percentage points above, and the stated range ends above it.
By their numbers in this assay, from the lowest: compound 3; then compounds 1 and 2 (each within the scatter of the next).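

In this assay, putting methylsulfonyl in place of methyl on this aromatic carbon brings a number 78.1 percentage points lower from compound 2 to compound 3 (beyond the scatter), a large step. Until now no change in a single place had been measured, and the high values of the first two compounds gave no hint of how much this position matters; this step shows that the high inhibition of the shared core does not survive every group placed on this carbon. Nothing measured here accounts for the drop.

Going by these compounds, only methyl and methylsulfonyl have been seen at this position, so it remains open whether the loss is particular to methylsulfonyl or would also appear with other groups there, such as a chlorine atom, a methoxy group, an amine or a carboxylic acid. Also open, on these data alone, is how the two compounds would compare as potencies, since each value comes from a single concentration, and whether methylsulfonyl would bring a similar step on the core of compound 1.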